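Trading a Nitrophenyl Group for a Chlorothiophene

This account rests on a few compounds, and the source may have more. Where it says the series, first, only, none or still open, it means among the compounds named here.

Within the data shown here, compound 2 `CCOC(=O)c1cnc(-c2cccc([N+](=O)[O-])c2)nc1NN1C(=O)C=C(C)C1=O` gives 7000 nM in a functional assay on Jurkat cells for inhibition of nuclear factor NF-kappa-B complex (Homo sapiens) (a higher number here means a weaker inhibitor, a lower number a stronger inhibitor), the higher of the two numbers measured so far. Compound 1 `CCOC(=O)c1cnc(-c2ccc(OC)cc2)nc1NN1C(=O)C=C(C)C1=O` gives 900 nM, and the step of a 7.8-fold higher number from compound 1 to compound 2 (0.89 log units; beyond the scatter) shows that changing the aryl group alone can move the number well beyond the scatter. Compound 3 `CCOC(=O)c1cnc(-c2ccc(Cl)s2)nc1NN1C(=O)C=C(C)C1=O` changes that same group again: 5-chlorothiophen-2-yl in place of 3-nitrophenyl on an aromatic carbon. Among the measured compounds shown here, no measured step covers this particular swap, so its direction rests only on compound 2 sitting at the weak end. Compound 3 is expected to give 3000 nM, within a range from 700 nM to 13000 nM. The step this estimate implies is expected to be a 2.3-fold lower number from compound 2 to compound 3 (0.37 log units; beyond the scatter).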

Compound 3, half-maximal inhibitory concentration: 300 nM
For compound 3 the middle estimate is 10-fold (1.00 log units) above the measured one, outside the stated range (below it).
By their numbers in this assay, from the lowest: compound 3; then compound 1; then compound 2.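

The 5-chlorothiophen-2-yl group gives a 23-fold lower number from compound 2 to compound 3 (1.37 log units; beyond the scatter) and also a 3.0-fold lower number from compound 1 to compound 3 (0.48 log units; beyond the scatter) in this assay, so compound 3 has the lowest number of the three. This position therefore takes a five-membered aromatic ring in place of a phenyl ring, and the choice of aryl group here can shift the number widely. No measurement on hand explains the gain. Still open, as far as these compounds go, is what the chlorine itself contributes, and whether a plain thiophene, or a methyl group or bromine in its place, would give a similar number.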